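Working notes on one antagonist series and a new analogue

A few compounds are considered here, and "the series" means these few. Any claim that something is new, unique, unknown or untested is made for them only; others in the source may bear on it.

Measured compounds:
Compound 1, `CCOCc1nc(Nc2ccc(C(F)(F)F)cc2)c2ccc(-c3ncccc3C(F)(F)F)cc2n1` — 0.9 nM
Compound 2, `CC(C)OCc1nc(Nc2ccc(C(F)(F)F)cc2)c2ccc(-c3ncccc3C(F)(F)F)cc2n1` — 0.3 nM
Compound 3, `O=C(O)COCc1nc(Nc2ccc(C(F)(F)F)cc2)c2ccc(-c3ncccc3C(F)(F)F)cc2n1` — 81 nM

In a functional assay for antagonist activity at transient receptor potential cation channel subfamily V member 1 (Homo sapiens) (a higher number here means a weaker inhibitor, a lower number a stronger inhibitor), compound 1 stands second highest of the three numbers. The nearest is a 3.0-fold lower number from compound 1 to compound 2 (0.48 log units; beyond the scatter), the furthest a 90-fold higher number from compound 1 to compound 3 (1.95 log units; beyond the scatter). The remaining step is a 270-fold higher number from compound 2 to compound 3 (2.43 log units; beyond the scatter).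

Compound 4, `CC(C)NCc1nc(Nc2ccc(C(F)(F)F)cc2)c2ccc(-c3ncccc3C(F)(F)F)cc2n1`, differs from compound 1 in one place: isopropylamino in place of ethoxy on a saturated chain carbon bound to an aromatic carbon. Among the compounds with values here, no measured step exchanges the chain oxygen for nitrogen, so the bearing of the known steps is indirect: a 3.0-fold lower number from compound 1 to compound 2 (0.48 log units; beyond the scatter) shows that an isopropyl on this chain is well accepted, while a 90-fold higher number from compound 1 to compound 3 (1.95 log units; beyond the scatter) shows a carboxy entering there costs much. Compound 4 carries no carboxy, so a small step is expected, a 2.2-fold higher number from compound 1 to compound 4 (0.35 log units; beyond the scatter), within or just beyond the scatter. Compound 4 is estimated at 2 nM, range 0.4 nM to 12 nM.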

Compound 4, half-maximal inhibitory concentration: 35 nM
Beside the measured number, compound 4's estimate is 18-fold (1.24 log units) below it; the whole stated range lies below it.
By their numbers in this assay, from the lowest: compound 2; then compound 1; then compound 4; then compound 3.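

In this assay the isopropyl accepted on the chain oxygen does not carry over to the chain nitrogen: isopropylamino in place of isopropoxy gives a large loss (a 120-fold higher number from compound 2 to compound 4 (2.07 log units; beyond the scatter)), and isopropylamino in place of ethoxy gives another (a 39-fold higher number from compound 1 to compound 4 (1.59 log units; beyond the scatter)). A loss of nearly carboxy size at this saturated chain carbon therefore occurs without a carboxy, and compound 4 remains only modestly ahead of the carboxymethoxy analogue (a 2.3-fold lower number from compound 3 to compound 4 (0.36 log units; beyond the scatter)). No evidence at hand accounts for this loss.

Open, on these data alone, is whether the loss follows the nitrogen or the hydrogen it carries. Methyl(isopropyl)amino or ethylamino at this place would help separate the two.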